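The source may report more compounds than this note shows. Statements on the series, on what has been measured and on what is new or still open speak of the compounds shown alone.

Among the measured compounds shown here, compound 3 `COc1cc(/C=C/C(=O)c2cccc(NC(=O)c3cc(Cl)cc(Cl)c3)c2)ccc1O` is one of three compounds measured in a functional assay on B16 cells (Mus musculus) for inhibition; a higher number here means a weaker inhibitor, a lower number a stronger inhibitor. In this assay compound 3 gives 4.83 ug/mL, the second highest number of the three. Compound 1 `COc1cc(/C=C/C(=O)c2cccc(NC(=O)c3ccc(Cl)c(Cl)c3)c2)ccc1O` gives 3.88 ug/mL, and compound 2 `COc1cc(/C=C/C(=O)c2cccc(N)c2)ccc1O`, which carries only a hydrogen on the aromatic nitrogen, gives 11.5 ug/mL. The step of a 1.2-fold higher number from compound 1 to compound 3 (0.10 log units; within the scatter) shows that moving the chlorines on the aryl amide made no visible difference, whereas a 3.0-fold higher number from compound 1 to compound 2 (0.47 log units; beyond the scatter) and a 2.4-fold lower number from compound 2 to compound 3 (0.38 log units; beyond the scatter) show that removing the whole aryl carbonyl costs a modest amount.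

Compound 4 `COc1cc(/C=C/C(=O)c2cccc(NC(=O)c3cccs3)c2)ccc1O` keeps the amide and changes only the aryl group: thiophen-2-yl in place of 3,5-dichlorophenyl on a carbonyl carbon. For the measured compounds named here, the one comparable step, from compound 1 to compound 3, was within the scatter, so a similar outcome is expected here, with the caveat that no measured pair removes the chlorines from the aryl amide altogether. Compound 4 is therefore expected to stay close to compound 3, with a 1.1-fold higher number from compound 3 to compound 4 (0.06 log units; within the scatter) taken as a small or no change, giving an estimated value of 5.5 ug/mL with a range from 3 ug/mL to 10 ug/mL.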

Compound 4, half-maximal inhibitory concentration: 6.93 ug/mL
The estimate for compound 4 lay 1.3-fold (0.10 log units) below the measured number, within the range that was stated.
By their numbers in this assay, from the lowest: compounds 1, 3, 4 and 2 (each within the scatter of the next, the first and the last beyond it).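

In this assay, a five-membered ring with sulfur can stand on the carbonyl carbon in place of a dichlorinated six-membered ring, as a 1.4-fold higher number from compound 3 to compound 4 (0.16 log units; within the scatter) and a 1.8-fold higher number from compound 1 to compound 4 (0.25 log units; within the scatter) both lie within the scatter. However, a 1.7-fold lower number from compound 2 to compound 4 (0.22 log units; within the scatter) also lies within the scatter, so unlike the two dichlorophenyl amides, the thiophen-2-yl amide cannot be separated from the free amine of compound 2. The benefit of acylating the nitrogen therefore shows clearly only for the dichlorophenyl amides, and nothing measured here bears on why.

On these data alone, it remains open whether an unsubstituted phenyl, a furan-2-yl or a plain acetyl on the nitrogen would fall with the dichlorophenyl amides or with compound 2. The role of the chlorines themselves also stays unresolved.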